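Tert-butyl in place of cyclopropyl: half-life notes

A few compounds are considered here, and "the series" means these few. Any claim that something is new, unique, unknown or untested is made for them only; others in the source may bear on it.

- compound 1 `CC(C)(C)n1nc(Oc2cc(Cl)ccn2)c2c(N)ncnc21`: 1 h
- compound 2 `CC(C)(C)n1nc(Oc2cc(O)ccn2)c2c(N)ncnc21`: 1.4 h
- compound 3 `N#Cc1ccnc(Oc2nn(C3CC3)c3ncnc(N)c23)c1`: > 2.41 h (a limit)

In an ADME assay on microsomes from liver (Homo sapiens) for metabolic stability, read by LC-MS, using NADPH, with a stated time of 10 min, tested at 10 uM (on this read-out lower numbers stand for a shorter-lived compound and higher numbers for a longer-lived compound), compound 3 stands at > 2.41 h, which is a limit of the assay and not a number.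

The next step leads to compound 4 `CC(C)(C)n1nc(Oc2cc(C#N)ccn2)c2c(N)ncnc21`, with tert-butyl in place of cyclopropyl on an aromatic nitrogen.

Among the compounds with values here, the one measured step is a 1.4-fold higher number from compound 1 to compound 2 (0.15 log units; within the scatter), with hydroxy in place of chloro on an aromatic carbon. Within the data shown here, that step does not cover the tert-butyl for cyclopropyl swap, so no measured step bears on it directly. It does show that two tert-butyl compounds, compound 1 at 1 h and compound 2 at 1.4 h, lie within the scatter of each other. Compound 4 also carries tert-butyl and is expected to lie near those two, which means a lower number than compound 3.

The expected change is an at least 1.6-fold lower number from compound 3 to compound 4 (0.20 log units; that floor lies within the scatter). The estimate for compound 4 is 1.5 h, with an expected range from 0.8 h to 2.8 h.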

Compound 4, half-life: > 2.41 h
Compound 4 was reported as a limit; the forecaster's own chance of this, stated with the estimate: 15%; middle value at least 1.6-fold (0.20 log units) from the limit.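

With tert-butyl held on the aromatic nitrogen, cyano in place of chloro on the aromatic carbon gives an at least 2.4-fold higher number from compound 1 to compound 4 (0.38 log units; beyond the scatter), and cyano in place of hydroxy gives an at least 1.7-fold higher number from compound 2 to compound 4 (0.23 log units; that floor lies within the scatter). A tert-butyl compound is therefore not tied to the half-lives of compound 1 and compound 2: the group on the other ring carbon can shift the read-out, at least for the chloro to cyano change. The swap of tert-butyl for cyclopropyl itself cannot be read in this assay, since compound 3 and compound 4 both rest on one limit of the assay and not on numbers: the limit of > 2.41 h in this assay, at which 2 of the 4 values shown sit.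

On these data alone, how far compound 3 and compound 4 lie past that limit stays open, and with it any effect of the tert-butyl swap. Also open, as far as these compounds go, is how an amine or a carboxylic acid at the cyano position, or a methyl on the aromatic nitrogen, would read.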